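The source may report more compounds than this note shows. Statements on the series, on what has been measured and on what is new or still open speak of the compounds shown alone.

Three compounds share one core and differ only in the aromatic group carried on an amine nitrogen in a ring. Compound 1 `CCCc1nc(-c2ccccc2)c(CNCCCN2CCN(c3ccc(F)cc3)CC2)o1` gives 62.5% in an assay on HEK293 cells for inhibition of Voltage-dependent T-type calcium channel subunit alpha-1G (Homo sapiens), read by fluorescence, tested at 10 uM; on this read-out lower numbers stand for less inhibition and higher numbers for more inhibition at the one concentration tested (going by the name of the read-out); compound 2 `CCCc1nc(-c2ccccc2)c(CNCCCN2CCN(c3ccc(C(F)(F)F)cc3)CC2)o1` gives 51.6% in this assay; compound 3 `CCCc1nc(-c2ccccc2)c(CNCCCN2CCN(c3ccc(C)cc3)CC2)o1` gives 53.9% in this assay. Compound 3 stands second highest of the three numbers: its nearest neighbour is compound 2, and a number 2.3 percentage points higher from compound 2 to compound 3 (within the scatter); its furthest is compound 1, and a number 8.6 percentage points lower from compound 1 to compound 3 (within the scatter). Among the measured compounds shown here, the only step beyond the scatter among the measured pairs is a number 10.9 percentage points lower from compound 1 to compound 2 (beyond the scatter).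

Compound 4 `CCCc1nc(-c2ccccc2)c(CNCCCN2CCN(c3ccccc3C)CC2)o1` is the next question. It differs from compound 3 by 2-methylphenyl in place of 4-methylphenyl on an amine nitrogen in a ring. The two have the same atoms, joined differently, and the place of the change is the same amine nitrogen in a ring. For the measured compounds named here, none of the measured steps bears directly on such a change: each of them exchanges one group for another of a different kind, and even the largest, a number 10.9 percentage points lower from compound 1 to compound 2 (beyond the scatter), is modest. Going by the values given here, nothing among the measured compounds argues for a shift beyond the scatter. Compound 4 is therefore expected to give 52% in this assay, with an expected range from 36% to 68%, which amounts to an expected step of a number 1.9 percentage points lower from compound 3 to compound 4 (within the scatter).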

Compound 4, a percentage reported as inhibition, at one concentration (the size of the read-out at that concentration, not a potency): 54.5%
Compound 4: the middle estimate sits 2.5 percentage points below what was measured, and the stated range covers the measured number.
By their numbers in this assay, from the lowest: compounds 2, 3, 4 and 1 (each within the scatter of the next, the first and the last beyond it).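

In this assay, 2-methylphenyl in place of 4-methylphenyl on the amine nitrogen in a ring gives a number 0.6 percentage points higher from compound 3 to compound 4 (within the scatter). Among the compounds shown here, this is the first measured change at this position that keeps the same atoms and only joins them differently, and this read-out does not tell the two methylphenyl groups apart. Compound 4 also lies within the scatter of the two compounds whose own step goes beyond it, with a number 2.9 percentage points higher from compound 2 to compound 4 (within the scatter) and a number 8 percentage points lower from compound 1 to compound 4 (within the scatter), so it does not add a second step beyond the scatter at this position, and nothing on hand accounts for the result.

The compounds shown leave open whether a substituent of another kind on the same aromatic ring, such as a methoxy group, an amine or a carboxylic acid, would stay within the scatter of these values as well. They also leave open how any of these compounds behaves at other concentrations, since each number here comes from a single tested concentration and says nothing about potency.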